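The source may hold more compounds than are shown below. What is called first, only, known or untested is meant among the compounds shown, and "the series" means these compounds.

Compound 1 `O=C(CCC1=CCN(CCCc2ccc(Cl)cc2)C1=O)NO` and compound 2 `CC(C)(C)c1ccc(CCCN2CC=C(CCC(=O)NO)C2=O)cc1` share one core and differ in a single group. In a functional assay on MDA-MB-231 cells (Homo sapiens) for inhibition, read by sulforhodamine B assay (on this read-out lower numbers stand for stronger inhibition of growth and higher numbers for weaker inhibition of growth), compound 1 gives 2210 nM and compound 2 gives 2210 nM. The change tert-butyl in place of chloro on an aromatic carbon thus made the step of no change at the digits printed from compound 1 to compound 2 (within the scatter). Compound 3 `O=C(CCC1=CCN(Cc2ccc(Cl)cc2)C1=O)NO` is built on another core; the difference between the two cores is not broken down here. In this assay, going by the values given here, compound 3 gives 1990 nM, a number within the scatter of the one for compound 1. Compound 4 `CC(C)(C)c1ccc(CN2CC=C(CCC(=O)NO)C2=O)cc1` carries the same change on the core of compound 3: tert-butyl in place of chloro on an aromatic carbon. On that basis compound 4 is expected to show a step of about a 1.0-fold higher number from compound 3 to compound 4 (0.00 log units; within the scatter), because no change at the digits printed from compound 1 to compound 2 (within the scatter) stayed within the scatter. The estimated value for compound 4 in this assay is 2000 nM.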

Compound 4, concentration for 50% growth inhibition: 690 nM
The estimate for compound 4 lay 2.9-fold (0.46 log units) above the measured number, outside the stated range (below it).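

In this assay, tert-butyl in place of chloro on the core of compound 3 gave a 2.9-fold lower number from compound 3 to compound 4 (0.46 log units; beyond the scatter), a modest gain in growth inhibition. So the effect of this change did not carry over unchanged from one core to the other, and an estimate borrowed from one core can mislead on the other: the same change on two cores in this assay, no change at the digits printed (within the scatter) from compound 1 to compound 2 and a 2.9-fold lower number (0.46 log units; beyond the scatter) from compound 3 to compound 4, 2.9-fold (0.46 log units) apart, beyond the scatter of two such steps. Going by these compounds alone, with only one pair on each core, this does not show why the two steps differ, nor how the change would behave on any further core.

The compounds shown leave open what a methoxy group or an amine would do in the same place on either core. They also leave open whether a longer chain would shift the step again.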